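Chloro to methyl on a shared core

A few compounds are considered here, and "the series" means these few. Any claim that something is new, unique, unknown or untested is made for them only; others in the source may bear on it.

Three measured compounds share one core. In a functional assay on HCT-116 cells (Homo sapiens) for antiproliferative activity, read by MTT assay, with a stated time of 72 h (on this read-out lower numbers stand for stronger inhibition and higher numbers for weaker inhibition), compound 1 `COc1ccc(/C=C2/CN(C)/C(=N/c3ccc(C)cc3)S2)cc1` gives 11100 nM, and compound 2 `COc1ccc(/C=C2/CN(C)/C(=N/c3ccc(Cl)cc3)S2)cc1` gives 9800 nM. Among the compounds with values here, the one measured step between single-change neighbours is a 1.1-fold lower number from compound 1 to compound 2 (0.05 log units; within the scatter). Compound 3 `COc1ccc(/C=C2\S/C(=N\c3ccc(Cl)cc3)N(C)C2=O)cc1` gives 10400 nM, the second highest of the three numbers, within the scatter of both others. Compound 4 `COc1ccc(/C=C2\S/C(=N\c3ccc(C)cc3)N(C)C2=O)cc1` differs from compound 3 by methyl in place of chloro on an aromatic carbon. Within the data shown here, the only step that bears on this change is the one between compound 1 and compound 2, run in the opposite direction, and it stayed within the scatter, so no step beyond the scatter is expected in this assay. The expected step is a 1.1-fold higher number from compound 3 to compound 4 (0.02 log units; within the scatter). Compound 4 is therefore estimated at 11000 nM, in the range 5500 nM to 22000 nM.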

Compound 4, half-maximal inhibitory concentration: > 100000 nM
Compound 4 ended at the assay's limit (the forecaster's own chance of this, stated with the estimate: 5%); at least 9.0-fold (0.95 log units) between middle value and limit.
By their numbers in this assay, from the lowest: compounds 2, 3 and 1 (each within the scatter of the next). At a limit, above all of these: compound 4.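

In this assay compound 4 gives > 100000 nM, which is a limit of the assay and not a number. Methyl in place of chloro on this aromatic carbon gives an at least 9.6-fold higher number from compound 3 to compound 4 (0.98 log units; beyond the scatter), although the same change stayed within the scatter on the other core. What this change does therefore depends on the core that carries it: the same change on two cores in this assay, a 1.1-fold lower number (0.05 log units; within the scatter) from compound 1 to compound 2 and an at least 9.6-fold lower number (0.98 log units; beyond the scatter) from compound 4 to compound 3, at least 8.4-fold (0.92 log units) apart, beyond the scatter of two such steps

As far as these compounds go, how an amine or a carboxylic acid at this place would read on either core stays open. So does how far the true value of compound 4 lies beyond its limit.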